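From propoxy to propargyloxy on the shared core

The source may report more compounds than this note shows. Statements on the series, on what has been measured and on what is new or still open speak of the compounds shown alone.

In a functional assay on HCT-116 cells (Homo sapiens) for inhibition, read by sulforhodamine B assay, with a stated time of 48 h, tested at 50 uM (on this read-out higher numbers stand for more inhibition of growth at the one concentration tested and lower numbers for less inhibition of growth), compound 1 (`CCCOc1ccc([C@@H]2CC(=O)c3cc(CC=C(C)C)c(OC)cc3O2)cc1`) gives 63%. Compound 2 (`COc1ccc([C@@H]2C/C(=N/OCc3cn(-c4ccc(O)cc4)nn3)c3cc(CC=C(C)C)c(OC)cc3O2)cc1`) gives 65%, within the usual scatter of compound 1, so these two numbers cannot be told apart. Compound 3 (`COc1cc2c(cc1CC=C(C)C)/C(=N/O)C[C@@H](c1ccc(O)cc1)O2`) gives 99%, which stands beyond the scatter from compound 1. Compound 1 therefore sits level with compound 2 and well short of compound 3. Within the data shown here, neither of these two neighbours differs from compound 1 in one place only, so no measured step speaks directly to the change at hand.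

Compound 4 (`C#CCOc1ccc([C@@H]2CC(=O)c3cc(CC=C(C)C)c(OC)cc3O2)cc1`) departs from compound 1 at a single place: ethynyl in place of ethyl on a saturated chain carbon bound to an oxygen on an aromatic ring. This is ethynyl in place of ethyl on a saturated chain carbon bound to an oxygen on an aromatic ring, or propoxy to propargyloxy when cut one bond further out. The rest of the structure stays as in compound 1.

Among the measured compounds shown here, with no measured precedent for this change, the expectation stays anchored on compound 1 at 63%. In this assay, the estimated step of a number 2 percentage points higher from compound 1 to compound 4 (within the scatter) is expected to stay within the scatter, with no firm direction. The expected value for compound 4 is 65%, with an estimated range of 47% to 83%.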

Compound 4, percent growth inhibition at one concentration: 75%
Compound 4: the middle estimate sits 10 percentage points below what was measured, within the range that was stated.
By their numbers in this assay, from the lowest: compounds 1, 2 and 4 (each within the scatter of the next, the first and the last beyond it); then compound 3.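

In this assay, the step of a number 12 percentage points higher from compound 1 to compound 4 (beyond the scatter) is modest but lies beyond the scatter, so the series now has a single-place comparison in which the outcome can be tied to one structural difference. It shows that the group on a saturated chain carbon bound to an oxygen on an aromatic ring is not silent in this read-out: with the rest of the structure held as in compound 1, propoxy to propargyloxy, with its one triple bond outside aromatic rings and no change in the counted hydrogen-bond donors or acceptors, raises growth inhibition at the one concentration tested. Nothing available bears on the reason for this step, so it stands as an observation from a single pair.

Still open, going by these compounds, is whether the triple bond itself matters or whether other groups at this place would read the same way, such as a longer chain like butoxy, or a chain ending in an amine or a carboxylic acid. Also open, on these data alone, is whether the same exchange gives a comparable step on a compound other than compound 1, since this one pair cannot show how far the result extends.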